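This account rests on a few compounds, and the source may have more. Where it says the series, first, only, none or still open, it means among the compounds named here.

For the measured compounds named here, compound 2 `COCCOC(=O)N1CCC(Oc2ncnc3c2CCN3c2ccc(S(C)(=O)=O)cc2F)CC1` gives 316 nM in a functional assay on CHO-K1 cells for agonist activity at Glucose-dependent insulinotropic receptor (Homo sapiens), read by a luciferase reporter, with a stated time of 5 h (on this read-out higher numbers stand for an effect only at larger amounts of compound and lower numbers for an effect already at smaller amounts), the higher of the two numbers so far. Compound 1 `CC(C)COC(=O)N1CCC(Oc2ncnc3c2CCN3c2ccc(S(C)(=O)=O)cc2F)CC1` in this assay gives 25.1 nM. Going by the values given here, the only measured step is a 13-fold higher number from compound 1 to compound 2 (1.10 log units; beyond the scatter). Compound 3 `CSC(=O)N1CCC(Oc2ncnc3c2CCN3c2ccc(S(C)(=O)=O)cc2F)CC1` is not yet measured; the change is methylsulfanyl in place of 2-methoxyethoxy on a carbonyl carbon. That one step, which exchanged a saturated chain for an ether chain, bears on this change only loosely, since here the ether chain leaves altogether and a sulfur group enters on the carbonyl carbon. Compound 3 is therefore expected at about 100 nM, between 30 nM and 400 nM, an estimated step of a 3.2-fold lower number from compound 2 to compound 3 (0.50 log units; beyond the scatter).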

Compound 3, half-maximal effective concentration: 251 nM
Beside the measured number, compound 3's estimate is 2.5-fold (0.40 log units) below it; low and high end bracket the measured number.
By their numbers in this assay, from the lowest: compound 1; then compounds 3 and 2 (each within the scatter of the next).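

In this assay, methylsulfanyl in place of 2-methoxyethoxy on the carbonyl carbon gives a 1.3-fold lower number from compound 2 to compound 3 (0.10 log units; within the scatter) and so does not separate these two groups, despite their different atoms. Methylsulfanyl in place of isobutoxy gives a 10-fold higher number from compound 1 to compound 3 (1.00 log units; beyond the scatter) and places isobutoxy apart from both other groups at this position. No evidence on hand accounts for these numbers.

Open, from the compounds shown here alone, is whether the sulfur or the chain sets the number here. Isobutylsulfanyl or methoxy on this carbonyl carbon would pull the two apart.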